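Chloro added between ring nitrogens of compound 2

The source may report more compounds than this note shows. Statements on the series, on what has been measured and on what is new or still open speak of the compounds shown alone.

Of the compounds shown here, three have numbers so far: compound 1 `ClCc1cccc(Cn2cnc3ncnc(Cl)c32)c1`, compound 2 `ClCc1cccc(Cn2cnc3c(Cl)ncnc32)c1` and compound 3 `ClCc1ccc(Cn2cnc3nc(Cl)nc(Cl)c32)cc1`. In a functional assay on SF-268 cells (Homo sapiens) for cytotoxicity, read by sulforhodamine B assay, with a stated time of 48 h (a lower number here means a stronger inhibitor of growth, a higher number a weaker inhibitor of growth), compound 1 gives 1650 nM. In this assay compound 2 gives 3540 nM, and compound 3 gives 1990 nM. Compound 2 stands at the upper end of these three numbers: compound 3 lies within the usual scatter of it, whereas compound 1 lies beyond the scatter on the lower side.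

Compound 4 `ClCc1cccc(Cn2cnc3c(Cl)nc(Cl)nc32)c1` is not yet measured. It differs from compound 2 by chloro in place of hydrogen on an aromatic carbon. Going by the values given here, no pair among the measured compounds differs in one place only, so no measured step covers this change. Compound 3 also carries two chloro groups on its core and gives 1990 nM in this assay, close to compound 2.

For compound 4 the step expected is a 1.4-fold lower number from compound 2 to compound 4 (0.15 log units; within the scatter), a small step toward a somewhat lower number. Compound 4 is therefore estimated at 2500 nM in this assay, with a range from 1000 nM to 6000 nM.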

Compound 4, concentration for 50% growth inhibition: 2510 nM
Compound 4: the middle estimate sits 1.0-fold (0.00 log units) below what was measured; measured number inside the range.
By their numbers in this assay, from the lowest: compounds 1, 3, 4 and 2 (each within the scatter of the next, the first and the last beyond it).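

Chloro in place of hydrogen on this aromatic carbon, between two ring nitrogen atoms, is the first single change in the series that can be read: in this assay it gives a step of a 1.4-fold lower number from compound 2 to compound 4 (0.15 log units; within the scatter). This position therefore carries a chloro group with growth inhibition held within the scatter, so neither a gain nor a loss can be claimed for the change. Nothing at hand accounts for this result.

On these data alone, it remains open whether this place tolerates other groups: an amine, a methoxy group or a longer chain here could give a step beyond the scatter, or none. As far as these compounds go, it is also open whether chloro would read the same way on compound 1 or compound 3, since each differs from compound 2 in more than one place.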